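This account rests on a few compounds, and the source may have more. Where it says the series, first, only, none or still open, it means among the compounds named here.

Compound 1 `O=C(CSc1nnc(NC(=O)C(Cl)Cl)s1)Nc1ccc(Br)cn1` and compound 2 `O=C(CSc1nnc(NC(=O)CCCl)s1)Nc1ccc(Br)cn1` share one core and differ only in the group attached to the carbonyl carbon of the amide. In a functional assay on HeLa cells (Homo sapiens) for antiproliferative activity, read by MTT assay, with a stated time of 48 h (a lower number here means a stronger inhibitor, a higher number a weaker inhibitor), compound 2 gives 5300 nM, while compound 1 gives 15200 nM. Among the measured compounds shown here, the step of a 2.9-fold higher number from compound 2 to compound 1 (0.46 log units; beyond the scatter) is the single change (dichloromethyl in place of 2-chloroethyl on a carbonyl carbon), and it moved the number upward by a modest amount that lies beyond the scatter.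

Compound 3 `O=C(CCCl)Nc1ccc(SCC(=O)Nc2ccc(Br)cn2)cc1` is built on a different core, and the difference between the two cores is not broken down here. In this assay compound 3 gives 15600 nM, which sits within the scatter of compound 1 and well above compound 2.

Compound 4 `O=C(CSc1ccc(NC(=O)C(Cl)Cl)cc1)Nc1ccc(Br)cn1` has not yet been measured. It relates to compound 3 exactly as compound 1 relates to compound 2: the change is dichloromethyl in place of 2-chloroethyl on a carbonyl carbon, and the surroundings of the place are the same, since in both pairs the carbonyl carbon carries an amide-type nitrogen as its other neighbour. Because a 2.9-fold higher number from compound 2 to compound 1 (0.46 log units; beyond the scatter) weakened inhibition on the first core, the same change on the core of compound 3 is expected to weaken it by a similar amount, giving an estimated step of a 2.7-fold higher number from compound 3 to compound 4 (0.43 log units; beyond the scatter). This expectation rests on a single pair, and the two cores differ in a way that is not resolved here, so the range is kept wide. Compound 4 is therefore estimated at 42000 nM in this assay, expected to fall between 15000 nM and 110000 nM.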

Compound 4, half-maximal inhibitory concentration: > 80000 nM
Compound 4 gave a limit, no number; the forecaster's own chance of this, stated with the estimate: 25%; middle value at least 1.9-fold (0.27 log units) from the limit.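

In this assay compound 4 gives > 80000 nM, which is a limit of the assay and not a number. Even so, dichloromethyl in place of 2-chloroethyl on a carbonyl carbon gives an at least 5.1-fold higher number from compound 3 to compound 4 (0.70 log units; beyond the scatter), which is the same direction as the step seen on the core of compound 1, and in both cases the change weakens inhibition. The direction of the change therefore carries from one core to the other in these two pairs, but this does not show whether its size carries over too, and two pairs alone cannot establish a rule for the series: the same change on two cores in this assay, a 2.9-fold higher number (0.46 log units; beyond the scatter) from compound 2 to compound 1 and an at least 5.1-fold higher number (0.70 log units; beyond the scatter) from compound 3 to compound 4; the limit leaves it open whether they differ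

The compounds shown place only 2-chloroethyl and dichloromethyl on this carbonyl carbon, which leaves open whether the same direction would appear with another group there, such as chloromethyl, trichloromethyl or a plain ethyl chain. Also open is how weak compound 4 really is, and with it how large its step is, since the reading stops at the limit of the assay: the limit of > 80000 nM in this assay, at which 1 of the 4 values shown sits.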